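A few compounds are considered here, and "the series" means these few. Any claim that something is new, unique, unknown or untested is made for them only; others in the source may bear on it.

Compound 1 `CCCCNC(=O)OCC1CN(C(=O)c2cc(OC)c(OC)c(OC)c2)CCN1C(=O)c1cc(OC)c(OC)c(OC)c1`: 240 nM
Compound 2 `CCCC(C)NC(=O)OCC1CN(C(=O)c2cc(OC)c(OC)c(OC)c2)CCN1C(=O)c1cc(OC)c(OC)c(OC)c1`: 100 nM

Both were tested in a functional assay (Oryctolagus cuniculus) for inhibition of platelet-activating factor receptor (Cavia porcellus); a higher number here means a weaker inhibitor, a lower number a stronger inhibitor. Compound 2 has the lowest number of the two, and its nearest neighbour is compound 1: a 2.4-fold lower number from compound 1 to compound 2 (0.38 log units; beyond the scatter), a step beyond the scatter. Compound 3 `CCC(C)(C)NC(=O)OCC1CN(C(=O)c2cc(OC)c(OC)c(OC)c2)CCN1C(=O)c1cc(OC)c(OC)c(OC)c1` has not yet been measured. It differs from compound 2 in one place only: 1,1-dimethylpropyl in place of 1-methylbutyl on an amide-type nitrogen. The two compounds hold the same atoms, joined differently, so the chain on the amide-type nitrogen is rearranged rather than lengthened or shortened. Among the compounds with values here, the only measured step that bears on this is the one from compound 1 to compound 2, where a single methyl placed on the chain carbon bound to that nitrogen gave a modest drop in the number. Whether a second methyl on that same carbon carries the trend further is not shown by the two values at hand. The expectation is therefore that compound 3 sits close to compound 2, with a 1.3-fold lower number from compound 2 to compound 3 (0.10 log units; within the scatter) expected to stay within the scatter. Compound 3 is estimated at 80 nM, with a range from 30 nM to 250 nM.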

Compound 3, half-maximal inhibitory concentration: 320 nM
Compound 3: middle estimate off by 4.0-fold (0.60 log units), on the low side; measured number outside the range, above it.
By their numbers in this assay, from the lowest: compound 2; then compounds 1 and 3 (each within the scatter of the next).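

In this assay, swapping 1-methylbutyl for 1,1-dimethylpropyl on the amide-type nitrogen keeps the same five carbons yet gives a 3.2-fold higher number from compound 2 to compound 3 (0.51 log units; beyond the scatter), so at this position the way the chain is arranged matters, not only how many carbons it holds. The step to the unbranched butyl chain, a 1.3-fold higher number from compound 1 to compound 3 (0.12 log units; within the scatter), means those two compounds cannot be told apart, and the difference seen earlier with a single added methyl, a 2.4-fold lower number from compound 1 to compound 2 (0.38 log units; beyond the scatter), does not carry over to compound 3. Across these three chains the number therefore does not fall steadily as branching on the carbon bound to that nitrogen increases, and compound 3 is the one that goes against such a trend.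

Nothing measured here explains why this position responds in this way. Still open, on these data alone, is how a ring such as cyclohexyl or cyclopentyl, a longer chain such as 1-methylhexyl, or an ether oxygen within the chain would behave on this same nitrogen, and whether any of them would give a lower number than compound 2 does.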